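Swapping trifluoromethyl for chloro on the aryl sulfonyl

The source may hold more compounds than are shown below. What is called first, only, known or untested is meant among the compounds shown, and "the series" means these compounds.

Measured in an ADME assay on L02 cells (Homo sapiens) for cytotoxicity, read by MTT assay, with a stated time of 24 h; on this read-out lower numbers stand for stronger inhibition and higher numbers for weaker inhibition:
- compound 1 `CN1C/C(=C\c2cccnc2)C(=O)/C(=C/c2ccccc2C(F)(F)F)C1`: 14100 nM
- compound 2 `O=C1/C(=C/c2cccnc2)CN(S(=O)(=O)c2ccc([N+](=O)[O-])cc2)C/C1=C\c1ccccc1C(F)(F)F`: 15700 nM
- compound 3 `O=C1/C(=C/c2cccnc2)CN(S(=O)(=O)c2ccc(C(F)(F)F)cc2)C/C1=C\c1ccccc1C(F)(F)F`: 14300 nM

Compound 3, at 14300 nM, cannot be told apart from compound 1 or compound 2, since all three values lie within the usual scatter of each other. The next compound, compound 4 `O=C1/C(=C/c2cccnc2)CN(S(=O)(=O)c2ccc(Cl)cc2)C/C1=C\c1ccccc1C(F)(F)F`, has chloro in place of trifluoromethyl on an aromatic carbon, para to a large group: chloro in place of trifluoromethyl on an aromatic carbon. For the measured compounds named here, no chloro compound has been measured yet, so the closest guide is a swap of the same kind, trifluoromethyl in place of nitro on an aromatic carbon, which gave a 1.1-fold lower number from compound 2 to compound 3 (0.04 log units; within the scatter). A change elsewhere in the molecule, (4-nitrophenyl)sulfonyl in place of methyl on an amine nitrogen in a ring, gave a 1.1-fold higher number from compound 1 to compound 2 (0.05 log units; within the scatter). Neither step left the scatter, so no step beyond the scatter is expected in this assay. The expected change is a 1.0-fold lower number from compound 3 to compound 4 (0.01 log units; within the scatter). For compound 4 the estimated value is 14000 nM, with an expected range from 9000 nM to 22000 nM.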

Compound 4, half-maximal inhibitory concentration: 11900 nM
Compound 4: the middle estimate sits 1.2-fold (0.07 log units) above what was measured; the range from low to high includes it.
By their numbers in this assay, from the lowest: compounds 4, 1, 3 and 2 (each within the scatter of the next).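

In this assay, putting chloro, a single heavy atom, where the four heavy atoms of trifluoromethyl stood on the aromatic carbon leaves the number within the scatter (a 1.2-fold lower number from compound 3 to compound 4 (0.08 log units; within the scatter)). Compound 4 is also within the scatter of the nitro compound (a 1.3-fold lower number from compound 2 to compound 4 (0.12 log units; within the scatter)) and of the compound with a methyl on the ring nitrogen (a 1.2-fold lower number from compound 1 to compound 4 (0.07 log units; within the scatter)), so all four compounds now sit together, and this position has accepted three different groups without a step beyond the scatter. Nothing measured here offers a reason for this.

Still open, as far as these compounds go, is whether an amine or a carboxylic acid on this aromatic carbon would move the number beyond the scatter. From the compounds shown here alone, it is also open whether a longer alkyl chain on the sulfonyl, in place of the aromatic ring, would do so.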